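Methyl on the phenyl of compound 1: expected effect

A few compounds are considered here, and "the series" means these few. Any claim that something is new, unique, unknown or untested is made for them only; others in the source may bear on it.

Compound 1 `O=C(NOCc1ccccc1Cl)c1cn(-c2ccccc2)nc1-c1ccccc1` gives 17800 nM in a functional assay on HeLa cells (Homo sapiens) for antiproliferative activity, read by MTT assay, with a stated time of 48 h, in the presence of a further agent that is not named here (a higher number here means a weaker inhibitor of growth, a lower number a stronger inhibitor of growth), the highest of the three numbers in this assay. Compound 2 `O=C(NOCc1ccc(Cl)cc1Cl)c1cn(-c2ccccc2)nc1-c1ccccc1` gives 5100 nM and compound 3 `Cc1ccc(-c2nn(-c3ccccc3)cc2C(=O)NOCc2ccccc2)cc1` gives 6690 nM. Among the measured compounds shown here, the one step along a single change, a 3.5-fold lower number from compound 1 to compound 2 (0.54 log units; beyond the scatter), concerns chloro, not the change at hand. Compound 4 `Cc1ccc(-c2nn(-c3ccccc3)cc2C(=O)NOCc2ccccc2Cl)cc1` differs from compound 1 by methyl in place of hydrogen on an aromatic carbon. For the measured compounds named here, no measured step covers this change directly; compound 3, which carries the same methyl group, sits below compound 1, but differs from it in a second place as well. Compound 4 is therefore expected to show a modest step downward, a 2.0-fold lower number from compound 1 to compound 4 (0.30 log units; within the scatter), with an estimated value of 9000 nM in this assay, within 4000 nM to 20000 nM.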

Compound 4, concentration for 50% growth inhibition: 4680 nM
The estimate for compound 4 lay 1.9-fold (0.28 log units) above the measured number; the measured number falls inside the stated range.
By their numbers in this assay, from the lowest: compounds 4, 2 and 3 (each within the scatter of the next); then compound 1.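

In this assay, methyl in place of hydrogen on an aromatic carbon, phenyl to 4-methylphenyl, now has a direct reading: a 3.8-fold lower number from compound 1 to compound 4 (0.58 log units; beyond the scatter). Chloro in place of hydrogen on an aromatic carbon now has a second reading, on the core carrying methyl, where it stays within the scatter: a 1.4-fold lower number from compound 3 to compound 4 (0.16 log units; within the scatter). The two chloro readings cannot be told apart: the same change on two cores in this assay, a 3.5-fold lower number (0.54 log units; beyond the scatter) from compound 1 to compound 2 and a 1.4-fold lower number (0.16 log units; within the scatter) from compound 3 to compound 4, 2.4-fold (0.39 log units) apart, within the scatter of two such steps

On these data alone, whether this step belongs to methyl alone remains open; an amine, a methoxy group or a longer chain at the same place would test that. As far as these compounds go, the methyl step on a core without chloro also remains open.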